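The source may hold more compounds than are shown below. What is called first, only, known or untested is meant among the compounds shown, and "the series" means these compounds.

Measured in a functional assay on MCF7 cells (Homo sapiens) for inhibition, read by sulforhodamine B assay; on this read-out lower numbers stand for stronger inhibition of growth and higher numbers for weaker inhibition of growth:
- compound 1 `COc1ccc(-c2ccc(-c3ccc(-c4nc5cc(C)ccc5[nH]4)cc3)cc2)cc1OC`: 190 nM
- compound 2 `COc1ccc(-c2ccc(-c3ccc(-c4nc5ccccc5[nH]4)cc3)cc2)cc1OC`: 7600 nM
- compound 3 `COc1ccc(-c2ccc(-c3ccc(-c4nc5c(O)cccc5[nH]4)cc3)cc2)cc1OC`: 190 nM

Compound 1, at 190 nM, stands level with compound 3, and these two share the lowest number of the three. Compound 2 lies far higher.

The next compound to be tested is compound 4 `Cc1ccc2[nH]c(-c3ccc(-c4ccc(-c5ccc(O)cc5)cc4)cc3)nc2c1`. It differs from compound 1 at one place, an aromatic carbon of a six-membered aromatic ring of carbon only, para to a large group, where 4-hydroxyphenyl sits in place of 3,4-dimethoxyphenyl: 4-hydroxyphenyl in place of 3,4-dimethoxyphenyl on an aromatic carbon.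

Within the data shown here, no measured step touches this group. The three steps available all change a different place on the molecule. Putting hydrogen in place of methyl gave a 40-fold higher number from compound 1 to compound 2 (1.60 log units; beyond the scatter), and putting hydroxy in place of hydrogen gave a 40-fold lower number from compound 2 to compound 3 (1.60 log units; beyond the scatter), while the comparison of the two substituted compounds gave no change at the digits printed from compound 1 to compound 3 (within the scatter). These steps show that a small edit can matter greatly among these compounds, but they give no size or direction for the new change, so any forecast must stay broad.

Among the measured compounds shown here, compound 1 already shares the lowest number so far, so a modest move upward in this assay seems the likeliest outcome. The expected step is a 2.4-fold higher number from compound 1 to compound 4 (0.37 log units; beyond the scatter). For compound 4 the estimated value is 450 nM, with an expected range of 70 nM to 3000 nM.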

Compound 4, concentration for 50% growth inhibition: 12100 nM
Compound 4: middle estimate off by 27-fold (1.43 log units), on the low side, outside the stated range (above it).
By their numbers in this assay, from the lowest: compounds 1 and 3 (each within the scatter of the next); then compounds 2 and 4 (each within the scatter of the next).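

In this assay, among these compounds, the swap of 3,4-dimethoxyphenyl for 4-hydroxyphenyl gives a 64-fold higher number from compound 1 to compound 4 (1.80 log units; beyond the scatter) and so shows that this end of the molecule, which no earlier step touched, can matter a great deal. The effect here is large, as it is at the other end of the molecule, where the loss of one methyl group gives a 40-fold higher number from compound 1 to compound 2 (1.60 log units; beyond the scatter) and the two results together mean that neither end can be treated as a spare place to edit in compound 1. The change is more than a single edit, since the entering group has fewer heavy atoms and adds a hydrogen-bond donor that the leaving group lacks, and no measurement at hand explains why the number rises so far.

The compounds shown do not separate the loss of the two methoxy groups from the arrival of the hydroxy group, so a plain phenyl ring, a phenyl ring with a single methoxy group or a phenyl ring with an amine would be the informative comparisons. Also open, going by these compounds, is whether the same swap would have a similar effect on the core of compound 3, which carries its hydroxy group on the other end of the molecule.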